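Adding a second carbamoyl to a triazene-bearing ring

A few compounds are considered here, and "the series" means these few. Any claim that something is new, unique, unknown or untested is made for them only; others in the source may bear on it.

Measured compounds:
compound 1, `CN(C)/N=N/c1cccc(C(N)=O)c1`, 3.8
compound 2, `CN(C)/N=N/c1ccc(C(N)=O)cc1`, 3.51
compound 3, `CN(C)/N=N/c1ccc(C(N)=O)cc1C(N)=O`, 3.27

Of the compounds shown here, three have been tested in a functional assay on L1210 cells (Mus musculus) for antiproliferative activity; on this read-out higher numbers stand for higher potency (the scale is a negative logarithm) and lower numbers for lower potency. Compound 1 `CN(C)/N=N/c1cccc(C(N)=O)c1` gives 3.8. Compound 2 `CN(C)/N=N/c1ccc(C(N)=O)cc1` gives 3.51, and compound 3 `CN(C)/N=N/c1ccc(C(N)=O)cc1C(N)=O` gives 3.27. The difference between the cores of compound 1 and compound 2 is not broken down here. From compound 2 to compound 3 the change is carbamoyl in place of hydrogen on an aromatic carbon, and it made a step of a number 0.24 log units lower from compound 2 to compound 3 (within the scatter).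

Compound 4 `CN(C)/N=N/c1cc(C(N)=O)cc(C(N)=O)c1` has not yet been measured. It differs from compound 1 by carbamoyl in place of hydrogen on an aromatic carbon. This is the same kind of change as from compound 2 to compound 3, but the surroundings differ: in compound 3 the entering group sits ortho to a group of 5 heavy atoms and meta to a carbamoyl group, whereas in compound 4 it sits meta to a carbamoyl group and meta to a group of 5 heavy atoms. Resting only on the step seen from compound 2 to compound 3, compound 4 is expected to show a step of about a number 0.25 log units lower from compound 1 to compound 4 (within the scatter) from compound 1, staying within the scatter. The estimated value for compound 4 in this assay is 3.55, between 3.2 and 3.9.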

Compound 4, logarithm of the reciprocal of the active concentration, log(1/C): 3.27
The estimate for compound 4 lay 0.28 log units above the measured number; measured number inside the range.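

Carbamoyl in place of hydrogen on an aromatic carbon gave a number 0.53 log units lower from compound 1 to compound 4 (beyond the scatter) in this assay. Set beside the earlier case, the change carries over to the second core in the same direction, and the two steps cannot be told apart in size: the same change on two cores in this assay, a number 0.24 log units lower (within the scatter) from compound 2 to compound 3 and a number 0.53 log units lower (beyond the scatter) from compound 1 to compound 4, 0.29 log units apart, within the scatter of two such steps Only the step on the core of compound 1 lies beyond the scatter, and two pairs cannot show that the change lowers the number on every core in this series, nor do they tell why it does so here.

The compounds shown leave open whether an amine or a carboxylic acid entering in place of the carbamoyl would give a step of similar size on these two cores. They also leave open whether a longer chain in place of the group of 5 heavy atoms would alter the step seen in this assay.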